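This account rests on a few compounds, and the source may have more. Where it says the series, first, only, none or still open, it means among the compounds named here.

Compound 1 `Cc1cc(Nc2ccc(C(=O)/C=C/c3ccc4ccccc4c3)cc2)n2nc(SCC(=O)c3ccccc3)nc2n1`: 190 nM
Compound 2 `Cc1cc(Nc2ccc(C(=O)/C=C/c3ccc(Cl)cc3)cc2)n2nc(SCc3nc4ccccc4[nH]3)nc2n1`: 230 nM

In a functional assay on SW-620 cells (Homo sapiens) for cytotoxicity, read by MTT assay, with stated times of 4 h and 72 h, tested at 2 uM (a lower number here means a stronger inhibitor, a higher number a weaker inhibitor), compound 1 gives 190 nM and compound 2 gives 230 nM. These two numbers lie within the usual scatter of each other, so compound 2 cannot be ranked against compound 1, even though their structures differ in more than one place.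

Compound 3 `Cc1cc(Nc2ccc(C(=O)/C=C/c3ccccc3Cl)cc2)n2nc(SCc3nc4ccccc4[nH]3)nc2n1` has the same atoms as compound 2, joined differently: 2-chlorophenyl in place of 4-chlorophenyl on a double-bonded chain carbon bound to a double-bonded chain carbon. In short, 2-chlorophenyl stands in place of 4-chlorophenyl on a double-bonded chain carbon bound to a double-bonded chain carbon.

Among the measured compounds shown here, no measured pair shows a single change of this kind, so the data offer no direct guide. In this assay, the expectation is therefore no step beyond the scatter, with only a slight lean towards a weaker number. The estimated step of a 1.2-fold higher number from compound 2 to compound 3 (0.09 log units; within the scatter) is small. For compound 3 the expected value is 280 nM, with an estimated range of 100 nM to 750 nM.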

Compound 3, half-maximal inhibitory concentration: 680 nM
Compound 3: the middle estimate sits 2.4-fold (0.39 log units) below what was measured; the range from low to high includes it.
By their numbers in this assay, from the lowest: compounds 1 and 2 (each within the scatter of the next); then compound 3.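

In this assay, moving the chlorine is enough to shift the result: 2-chlorophenyl in place of 4-chlorophenyl on a double-bonded chain carbon bound to a double-bonded chain carbon gives a 3.0-fold higher number from compound 2 to compound 3 (0.47 log units; beyond the scatter). Among the compounds shown here, this is the first comparison here of two compounds that differ in one place, and it shows that this end of the molecule responds to how the atoms are joined, as the two groups hold the same atoms. Nothing measured here explains this step.

The compounds shown leave open whether the chlorine is needed at all, and whether a fluorine or a methoxy group on the same ring would follow the same order. For the compounds shown here, a single pair also cannot tell whether the same change would give a similar step with the other sulfur-linked side chain, the one carried by compound 1.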